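Shortening a chloropropyl urea chain to ethyl

The compounds below may be only part of what the source reports. "The series", "measured", "known", "first", "only" and "open" are said of these compounds alone.

Three aryl ureas have been run in a functional assay on MCF7 cells (Homo sapiens) for antiproliferative activity, with a stated time of 48 h; a higher number here means a weaker inhibitor, a lower number a stronger inhibitor. Compound 1 `CC(C)(C)c1ccc(NC(=O)NCCCCl)cc1` gives 49000 nM, compound 3 `CCCCCc1cccc(NC(=O)NCCCCl)c1` gives 26000 nM, and compound 2 `CC(C)(C)c1ccc(CNC(=O)NCCCCl)cc1` gives 17000 nM. Compound 2 thus carries the lowest number of the three, though compound 3 stands within the scatter of it and only compound 1 lies beyond it.

Compound 4 `CCNC(=O)NCc1ccc(C(C)(C)C)cc1` is yet to be measured in this assay. It differs from compound 2 in one place: hydrogen in place of chloromethyl on a saturated chain carbon, two bonds along the chain from an amide-type nitrogen, so that the 3-chloropropyl arm becomes ethyl. No comparable step has been measured among these compounds, so there is no direct precedent for its size. Since the three measured ureas all share the chloropropyl arm, its removal is expected to push the number upward, by a moderate step from compound 2 to compound 4 of a 2.6-fold higher number from compound 2 to compound 4 (0.42 log units; beyond the scatter). Compound 4 is therefore estimated to give about 45000 nM in this assay, within a range of 15000 nM to 130000 nM.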

Compound 4, half-maximal inhibitory concentration: > 100000 nM
Compound 4 ended at the assay's limit (the forecaster's own chance of this, stated with the estimate: 30%); at least 2.2-fold (0.34 log units) between middle value and limit.
By their numbers in this assay, from the lowest: compounds 2, 3 and 1 (each within the scatter of the next, the first and the last beyond it). At a limit, above all of these: compound 4.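

In this assay compound 4 gives > 100000 nM, which is a limit of the assay and not a number. Hydrogen in place of chloromethyl, on a saturated chain carbon two bonds along the chain from an amide-type nitrogen, brings an at least 5.8-fold higher number from compound 2 to compound 4 (0.76 log units; beyond the scatter). The earlier compounds all carried the 3-chloropropyl arm and could say nothing about it, whereas this single change shows that the activity of compound 2 is not kept with an ethyl arm, and the step gives only a lower bound on the change: the limit of > 100000 nM in this assay, at which 1 of the 4 values shown sits.

The chlorine and the chain length change together in this step, so the compounds shown leave open which of the two matters. A propyl arm would keep the chain without the chlorine, and a 2-chloroethyl arm would keep the chlorine on a shorter chain.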